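Cyano in place of bromo on the sulfonyl ring

A few compounds are considered here, and "the series" means these few. Any claim that something is new, unique, unknown or untested is made for them only; others in the source may bear on it.

Compound 1, `Cc1ccc(S(=O)(=O)N2C/C(=C\c3cccc(F)c3)C(=O)/C(=C/c3cccc(F)c3)C2)cc1`: in an ADME assay on L02 cells (Homo sapiens) for cytotoxicity, read by MTT assay, with a stated time of 24 h (a higher number here means a weaker inhibitor, a lower number a stronger inhibitor), compound 1 gives 15700 nM.
Compound 2, `O=C1/C(=C/c2cccc(F)c2)CN(S(=O)(=O)c2ccc(O[N+](=O)[O-])cc2)C/C1=C\c1cccc(F)c1`: compound 2 gives 10700 nM.
Compound 3, `O=C1/C(=C/c2cccc(F)c2)CN(S(=O)(=O)c2ccc(Br)cc2)C/C1=C\c1cccc(F)c1`: compound 3 gives 15800 nM.

Compound 3 carries the highest of these three numbers, yet it cannot be set apart from the others: the step of a 1.0-fold higher number from compound 1 to compound 3 (0.00 log units; within the scatter) and the step of a 1.5-fold higher number from compound 2 to compound 3 (0.17 log units; within the scatter) both fall within the scatter, as does the step of a 1.5-fold lower number from compound 1 to compound 2 (0.17 log units; within the scatter). All three measured changes sit on the same aromatic carbon of the sulfonyl-bearing ring, and none of them moved the read-out beyond what repeated measurements would show.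

Compound 4, `N#Cc1ccc(S(=O)(=O)N2C/C(=C\c3cccc(F)c3)C(=O)/C(=C/c3cccc(F)c3)C2)cc1`, differs from compound 3 in that same place: cyano in place of bromo on an aromatic carbon. Within the data shown here, no measured step exchanges bromo for cyano, so the bearing of the earlier steps is indirect, but all of them, methyl, nitrooxy and bromo, left the number where it was. On that basis the step of a 1.1-fold lower number from compound 3 to compound 4 (0.05 log units; within the scatter) is expected to stay within the scatter, with no direction favoured. Compound 4 is therefore estimated at 14000 nM, with a range from 7000 nM to 28000 nM.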

Compound 4, half-maximal inhibitory concentration: 15500 nM
Estimate against measurement, compound 4: 1.1-fold (0.04 log units) below; measured number inside the range.
By their numbers in this assay, from the lowest: compounds 2, 4, 1 and 3 (each within the scatter of the next).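

Cyano is the first group in this set to bring a triple bond and a hydrogen-bond acceptor to this aromatic carbon, where bromo counts neither, and in this assay the direct exchange gives a 1.0-fold lower number from compound 3 to compound 4 (0.01 log units; within the scatter) and so does not separate the two groups. The comparisons with the other two groups agree, with a 1.0-fold lower number from compound 1 to compound 4 (0.01 log units; within the scatter) for cyano in place of methyl and a 1.4-fold higher number from compound 2 to compound 4 (0.16 log units; within the scatter) for cyano in place of nitrooxy. Among these compounds, all four groups on this aromatic carbon therefore fall within the scatter of one another, no compound among the four goes against this, and adding an acceptor and a second heavy atom to the substituent does not move the read-out beyond the scatter.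

The compounds shown leave open whether an amine, a carboxylic acid or a longer chain such as butoxy on the same aromatic carbon would also fall with these four. They also leave open how the read-out answers to a change elsewhere, since all four share the rest of the core unaltered.

No measurement offered here accounts for these numbers.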